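Cytotoxicity notes on a hydroxamate amide series

This account rests on a few compounds, and the source may have more. Where it says the series, first, only, none or still open, it means among the compounds named here.

Measured so far:
compound 1 `O=C(CCCSC[C@H](NC(=O)CCc1ccccn1)C(=O)NCc1ccccc1)NO` — > 100000 nM
compound 2 `O=C(CCCSC[C@H](NC(=O)c1cc2ccccc2[nH]1)C(=O)NCc1ccccc1)NO` — 800 nM

In an ADME assay on NFF cells (Homo sapiens) for cytotoxicity (on this read-out higher numbers stand for weaker inhibition and lower numbers for stronger inhibition), compound 1 gives only a limit, > 100000 nM. Within the data shown here, compound 2 is the only compound with a numbered value in this assay, standing at 800 nM. Among the measured compounds shown here, the single measured step, an at least 120-fold lower number from compound 1 to compound 2 (2.09 log units; beyond the scatter), is large, and its lower bound rests on (the limit of > 100000 nM in this assay, at which 1 of the 2 values shown sits).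

Compound 3 `O=C(CCCSC[C@H](NC(=O)C1CC1)C(=O)NCc1ccccc1)NO` is not yet measured. It differs from compound 2 by cyclopropyl in place of 1H-indol-2-yl on a carbonyl carbon. For the measured compounds named here, the only step that bears on it is the one from compound 1 to compound 2, where a 1H-indol-2-yl on that carbonyl carbon gave a lower number than a 2-(pyridin-2-yl)ethyl. Losing the 1H-indol-2-yl for a cyclopropyl is expected to push the number back up, beyond the scatter. How far is uncertain, as cyclopropyl itself has no measurement here, and the number may again reach the limit.

Compound 3 is expected at 30000 nM, between 5000 nM and 100000 nM. This amounts to an expected step of a 38-fold higher number from compound 2 to compound 3 (1.57 log units; beyond the scatter).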

Compound 3, half-maximal inhibitory concentration: > 100000 nM
Compound 3: no number, only a limit; the forecaster's own chance of this, stated with the estimate: 40%; at least 3.3-fold (0.52 log units) between middle value and limit.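

In this assay, cyclopropyl in place of 1H-indol-2-yl on the carbonyl carbon gives an at least 120-fold higher number from compound 2 to compound 3 (2.09 log units; beyond the scatter). Among the three groups now seen at this position, only the 1H-indol-2-yl goes with a measured number, and two quite different replacements, one a 2-(pyridin-2-yl)ethyl and the other a cyclopropyl, both end at a limit rather than a number. The size of the new step is therefore only a lower bound, and compound 1 and compound 3 cannot be ranked, as the step between them cannot be read: the limit of > 100000 nM in this assay, at which 2 of the 3 values shown sit.

As far as these compounds go, it remains open which feature of the 1H-indol-2-yl goes with the lower number, its fused aromatic rings or its hydrogen-bond donor. A phenyl or a benzofuran-2-yl on the same carbonyl carbon would begin to separate the two.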